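Methylsulfanyl to dimethylamino: the next step in the series

The compounds below may be only part of what the source reports. "The series", "measured", "known", "first", "only" and "open" are said of these compounds alone.

In a functional assay on DU-145 cells (Homo sapiens) for inhibition, read by trypan blue exclusion, with a stated time of 96 h (on this read-out lower numbers stand for stronger inhibition of growth and higher numbers for weaker inhibition of growth), compound 1 `Cc1ccc(S(=O)(=O)/C(=C/c2c(O)cc(O)cc2O)C(=O)c2ccc(Br)cc2)cc1` gives > 100000 nM, which is a limit of the assay and not a number. Compound 2 `Cc1ccc(S(=O)(=O)/C(=C/c2ccc(Br)cc2)C(=O)c2ccc(Br)cc2)cc1` reads 10000 nM. For the measured compounds named here, compound 3 `CSc1ccc(/C=C(\C(=O)c2ccc(Br)cc2)S(=O)(=O)c2ccc(C)cc2)cc1` reads 1000 nM, the lowest number so far, and the only other number in the set is that of compound 2.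

Compound 4 `Cc1ccc(S(=O)(=O)/C(=C/c2ccc(N(C)C)cc2)C(=O)c2ccc(Br)cc2)cc1` differs from compound 3 by one exchange: dimethylamino in place of methylsulfanyl on an aromatic carbon. In words, dimethylamino stands in place of methylsulfanyl on an aromatic carbon, para to a large group.

No dimethylamino group has been measured yet, so the evidence is indirect. All three measured steps change the group at this same place. The first is an at least 10-fold lower number from compound 1 to compound 2 (1.00 log units; beyond the scatter), which is at least modest. The second is an at least 100-fold lower number from compound 1 to compound 3 (2.00 log units; beyond the scatter), which is large. Going by the values given here, the closest precedent is a 10-fold lower number from compound 2 to compound 3 (1.00 log units; beyond the scatter), a modest step that exchanges one single substituent for another.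

With compound 3 at 1000 nM as the lowest number, a change away from methylsulfanyl is expected to raise the number slightly rather than lower it further. The expected step is a 2.0-fold higher number from compound 3 to compound 4 (0.30 log units; within the scatter), smaller than the modest one and uncertain in size. For compound 4 the estimated value is 2000 nM, with an expected range of 300 nM to 10000 nM.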

Compound 4, concentration for 50% growth inhibition: 50000 nM
For compound 4 the middle estimate is 25-fold (1.40 log units) below the measured one; measured number outside the range, above it.
By their numbers in this assay, from the lowest: compound 3; then compound 2; then compound 4. At a limit, above all of these: compound 1.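

Position notes: in this assay, the place on an aromatic carbon para to a large group proves far more sensitive to the choice of single substituent than the bromo and methylsulfanyl pair alone showed, with a 50-fold higher number from compound 3 to compound 4 (1.70 log units; beyond the scatter) marking the largest single-substituent exchange in the set. Methylsulfanyl and dimethylamino carry the same counts of hydrogen-bond donors and acceptors and neither has a net charge, yet they read far apart, and dimethylamino also falls behind bromo, with a 5.0-fold higher number from compound 2 to compound 4 (0.70 log units; beyond the scatter) placing bromo between the other two substituents, so these counts do not track the order here. Compound 1 remains a limit of the assay and not a number, so an at least 2.0-fold lower number from compound 1 to compound 4 (0.30 log units; that floor lies within the scatter) gives only a floor for that comparison: the limit of > 100000 nM in this assay, at which 1 of the 4 values shown sits.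

The compounds shown leave open how methoxy, ethylsulfanyl or an unsubstituted amine would read at this place, and so whether the low number of compound 3 belongs to methylsulfanyl alone or extends to its close relatives. From the compounds shown here alone, it also remains open whether the same order of substituents would hold with a group other than 4-bromophenyl on the carbonyl.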